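Acylselenourea series: benzyl to methyl on selenium

The compounds below may be only part of what the source reports. "The series", "measured", "known", "first", "only" and "open" are said of these compounds alone.

Measured in a functional assay on HepG2 cells (Homo sapiens) for cytotoxicity, read by MTT assay, with a stated time of 72 h; a lower number here means a stronger inhibitor of growth, a higher number a weaker inhibitor of growth:
compound 1 `C[Se]/C(=N\C(=O)c1cc2ccccc2s1)NC(=O)c1cc2ccccc2s1` gives 41000 nM
compound 2 `O=C(/N=C(/NC(=O)c1csc([N+](=O)[O-])c1)[Se]Cc1ccccc1)c1csc([N+](=O)[O-])c1` gives 62800 nM
compound 3 `O=C(/N=C(/NC(=O)c1cc2ccccc2s1)[Se]Cc1ccccc1)c1cc2ccccc2s1` gives 49000 nM

Compound 3 and compound 1 share one core and differ by hydrogen in place of phenyl on a saturated chain carbon bound to a selenium atom; the step was a 1.2-fold lower number from compound 3 to compound 1 (0.08 log units; within the scatter). Compound 2 rests on a different core; how the core of compound 2 differs from that of compound 3 is not broken down here. Compound 4 `C[Se]/C(=N\C(=O)c1csc([N+](=O)[O-])c1)NC(=O)c1csc([N+](=O)[O-])c1` carries the same change made on compound 2: hydrogen in place of phenyl on a saturated chain carbon bound to a selenium atom. The place reads the same for both pairs, so the change is the same. The step expected in this assay is of like size, because the earlier one was a 1.2-fold lower number from compound 3 to compound 1 (0.08 log units; within the scatter), namely a 1.2-fold lower number from compound 2 to compound 4 (0.07 log units; within the scatter). Compound 4 is therefore estimated at 53000 nM, expected to fall between 30000 nM and 95000 nM.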

Compound 4, concentration for total growth inhibition: 1550 nM
Compound 4: middle estimate off by 34-fold (1.53 log units), on the high side; measured number outside the range, below it.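

In this assay, hydrogen in place of phenyl on a saturated chain carbon bound to a selenium atom gave a 41-fold lower number from compound 2 to compound 4 (1.61 log units; beyond the scatter) and so did not repeat the small step seen on the other core. Across these two cores, the size of the benzyl to methyl change depends on the core that carries it: the same change on two cores in this assay, a 1.2-fold lower number (0.08 log units; within the scatter) from compound 3 to compound 1 and a 41-fold lower number (1.61 log units; beyond the scatter) from compound 2 to compound 4, 34-fold (1.53 log units) apart, beyond the scatter of two such steps

Two pairs do not show which difference between the cores sets the size of the step, and no general gain from methyl follows, with compound 3 and compound 1 going against one.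

As far as these compounds go, it remains open whether ethyl or a longer chain in the same place would keep the low number of compound 4. Also open, from the compounds shown here alone, is how other groups in that place, such as a carboxylic acid or an amine at the end of the chain, would behave on either core.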